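A 4-methoxyphenyl in place of 2-chlorophenyl

The source may report more compounds than this note shows. Statements on the series, on what has been measured and on what is new or still open speak of the compounds shown alone.

Measured so far in a functional assay on MIA PaCa-2 cells (Homo sapiens) for inhibition, read by MTT assay, with a stated time of 72 h, tested at 30 uM; a lower number here means less inhibition of growth, a higher number more inhibition of growth at the concentration tested:
Compound 1 `C=CCc1ccc(OCc2cn(-c3ccc(C#N)cc3)nn2)c(O)c1`: 39.3%
Compound 2 `C=CCc1ccc(OCc2cn(-c3ccccc3Cl)nn2)c(O)c1`: 46.6%

Compound 2 stands at 46.6% and compound 1 at 39.3%, so the two lie within the scatter of each other and neither can be placed ahead. The next compound to be tested, compound 3 `C=CCc1ccc(OCc2cn(-c3ccc(OC)cc3)nn2)c(O)c1`, keeps the shared core and differs from compound 2 at the group on the aromatic nitrogen: 4-methoxyphenyl in place of 2-chlorophenyl on an aromatic nitrogen. Within the data shown here, only one measured step bears on this change. It also exchanges one substituted phenyl group for another at that nitrogen, and it amounts to a number 7.3 percentage points higher from compound 1 to compound 2 (within the scatter). Two compounds are a thin basis, and they do not show how a 4-methoxyphenyl group will behave. Among the measured compounds shown here, because a number 7.3 percentage points higher from compound 1 to compound 2 (within the scatter) is the only exchange measured at this place, no step beyond the scatter is expected, and no firm direction can be given. The expected change is small, at a number 3.6 percentage points lower from compound 2 to compound 3 (within the scatter) in this assay. For compound 3 the estimated value is 43%, with an expected range of 30% to 56%.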

Compound 3, percent growth inhibition at one concentration: 62.3%
Beside the measured number, compound 3's estimate is 19.3 percentage points below it; measured number above the stated range.
By their numbers in this assay, from the lowest: compounds 1 and 2 (each within the scatter of the next); then compound 3.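

The two earlier compounds gave no sign that the group on the aromatic nitrogen affects growth inhibition, as their gap stayed within the scatter. In this assay, this position proves responsive, with a number 15.7 percentage points higher from compound 2 to compound 3 (beyond the scatter) when 4-methoxyphenyl replaces 2-chlorophenyl, and compound 3 stands above both other compounds by steps beyond the scatter. The exchange of methoxy for cyano on an aromatic carbon gives a number 23 percentage points higher from compound 1 to compound 3 (beyond the scatter), so a change of that single group is enough to move the result beyond the scatter, though no measurement here explains the gain.

Among these compounds, with only three substituted phenyl groups at this position, the compounds leave open whether the methoxy group itself or its place on the phenyl group accounts for the higher number, a question that 2-methoxyphenyl and 4-chlorophenyl would help to settle. They also leave open how an unsubstituted phenyl, a 4-ethoxyphenyl with its longer chain or a 4-aminophenyl would compare with 4-methoxyphenyl, and whether the gain would persist in full dose-response measurements.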